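Methoxy in place of chloro on compound 1

A few compounds are considered here, and "the series" means these few. Any claim that something is new, unique, unknown or untested is made for them only; others in the source may bear on it.

Compound 1 `CS(=O)(=O)Nc1ccc(Cl)c2c1CCCC2c1c[nH]cn1` was tested in an assay on isolated protein for binding affinity to Alpha-1A adrenergic receptor (Rattus norvegicus), read by radioligand binding (on this read-out lower numbers stand for stronger inhibition and higher numbers for weaker inhibition), where compound 1 gives 447 nM. Among the measured compounds shown here, that is the lowest of the three numbers known. Compound 2 `CS(=O)(=O)Nc1cccc2c1CCCC2C1=NCCN1` gives 457 nM in this assay, a number within the scatter of that of compound 1, so the two cannot be told apart. Compound 3 `CC(C)S(=O)(=O)Nc1cccc2c1CCCC2c1c[nH]cn1` gives 1150 nM in this assay, a gap to compound 1 that lies beyond the scatter. Compound 4 `COc1ccc(NS(C)(=O)=O)c2c1C(c1c[nH]cn1)CCC2` has not yet been measured. It differs from compound 1 in one place: methoxy in place of chloro on an aromatic carbon. For the measured compounds named here, no measured pair shows this change, so its effect is unknown. The step of a 1.3-fold higher number from compound 1 to compound 4 (0.13 log units; within the scatter) is expected to be small, toward a slightly higher number, hardly beyond the scatter. Compound 4 is estimated at 600 nM, within a range from 200 nM to 1800 nM.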

Compound 4, inhibition constant: 1700 nM
Compound 4: middle estimate off by 2.8-fold (0.45 log units), on the low side, within the range that was stated.
By their numbers in this assay, from the lowest: compounds 1 and 2 (each within the scatter of the next); then compounds 3 and 4 (each within the scatter of the next).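

In this assay the aromatic carbon para to a methanesulfonamido group proves not to be indifferent to its substituent: methoxy in place of chloro gives a 3.8-fold higher number from compound 1 to compound 4 (0.58 log units; beyond the scatter) and this step lies beyond the scatter. Among the compounds shown here, it is the first evidence on this position, and chloro there gives the lower number of the two groups. Nothing measured bears on the reason for this step. The compounds shown leave open how fluoro, an amine or a nitrile on this aromatic carbon would read, and whether the methoxy step holds on other cores.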